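Swapping One Phenyl Group and Watching Cell Tolerance

This account rests on a few compounds, and the source may have more. Where it says the series, first, only, none or still open, it means among the compounds named here.

In an ADME assay on HepG2 cells (Homo sapiens) for cytotoxicity, read by XTT assay, with a stated time of 2 days (a lower number here means that less compound is tolerated, a higher number that more compound is tolerated), compound 1 `Cc1c(C(=O)Nc2ccccc2)sc(N)c1C(=O)Nc1ccccc1` gives > 100000 nM. This is a limit of the assay and not a number, and it places compound 1 at the limit of > 100000 nM in this assay, at which 1 of the 3 values shown sits.

Compound 4 `Cc1cc(NC(=O)c2c(N)sc(C(=O)Nc3ccccc3)c2C)ccc1F` keeps the core of compound 1 and changes one group: 4-fluoro-3-methylphenyl in place of phenyl on an amide-type nitrogen. In words, this is 4-fluoro-3-methylphenyl in place of phenyl on an amide-type nitrogen.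

Among the measured compounds shown here, the one measured step that bears on this change comes from compound 2 `Cc1c(C(=O)Nc2ccc(F)c(F)c2)sc(N)c1C(=O)Nc1ccccc1`, which carries 3,4-difluorophenyl in place of phenyl on an amide-type nitrogen and gives 26000 nM. That step is an at least 3.8-fold lower number from compound 1 to compound 2 (0.58 log units; beyond the scatter). Compound 3 `Cc1c(C(=O)Nc2ccc(F)c(F)c2)sc(N)c1C(=O)Nc1ccc(Cl)cc1` adds nothing here, since compound 3 has "not determined" (no result reported).

The group in compound 2 is only a similar one, and a single step is thin support, so a step of comparable size toward a lower number is expected, with wide uncertainty. The estimated step is an at least 2.8-fold lower number from compound 1 to compound 4 (0.45 log units; beyond the scatter). For compound 4 the expected value is 35000 nM, with an estimated range of 12000 nM to 100000 nM.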

Compound 4, half-maximal cytotoxic concentration: 40000 nM
Beside the measured number, compound 4's estimate is 1.1-fold (0.06 log units) below it; the measured number falls inside the stated range.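

The change to 4-fluoro-3-methylphenyl brings an at least 2.5-fold lower number from compound 1 to compound 4 (0.39 log units; beyond the scatter), so in this assay a lower number no longer rests on 3,4-difluorophenyl alone. Compound 2 gives 26000 nM and compound 4 gives 40000 nM, two values within the usual scatter of each other, so these two groups cannot be told apart here. Compound 1 stands at a limit of the assay and not at a number, so each step from it shows only the least size the step can have: the limit of > 100000 nM in this assay, at which 1 of the 4 values shown sits.

Still open, on these data alone, is whether the fluorine or the methyl group accounts for the step, as the two arrive together in compound 4. Also open, as far as these compounds go, is how a phenyl carrying an amine or a carboxylic acid would read on this same nitrogen.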